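From cyano to 2-carboxyethenyl in a cytotoxic series

The compounds below may be only part of what the source reports. "The series", "measured", "known", "first", "only" and "open" are said of these compounds alone.

Measured in a functional assay on CLL cells (Homo sapiens) for cytotoxicity, read by MTT assay, with a stated time of 48 h; a higher number here means that more compound is needed for the effect, a lower number that less compound is needed:
compound 1 `C=C(CC)C(=O)c1ccc(OCC(=O)Nc2ccc(S(=O)(=O)O)cc2)c(Cl)c1Cl`: > 25000 nM (a limit of the assay)
compound 2 `C=C(CC)C(=O)c1ccc(OCC(=O)Nc2ccc(/C=C/C(=O)OCC)cc2)c(Cl)c1Cl`: 1700 nM
compound 3 `C=C(CC)C(=O)c1ccc(OCC(=O)Nc2ccc(C#N)cc2)c(Cl)c1Cl`: 7800 nM

Compound 3, at 7800 nM, has the higher of the two true numbers, so more of it is needed than of compound 2. Compound 1 stands at a limit, > 25000 nM, not at a number.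

Compound 4 `C=C(CC)C(=O)c1ccc(OCC(=O)Nc2ccc(/C=C/C(=O)O)cc2)c(Cl)c1Cl` differs from compound 3 in one place: 2-carboxyethenyl in place of cyano on an aromatic carbon. A 2-carboxyethenyl group replaces cyano on an aromatic carbon.

Among the measured compounds shown here, three measured steps bear on this. Putting cyano in place of 2-(ethoxycarbonyl)ethenyl gave a 4.6-fold higher number from compound 2 to compound 3 (0.66 log units; beyond the scatter), which favours the ethenyl chain that compound 4 keeps. However, compound 4 lacks the ethyl ester, and its free end looks more like the sulfo group of compound 1. Replacing that sulfo group gave an at least 14-fold lower number from compound 1 to compound 2 (1.16 log units; beyond the scatter) and an at least 3.2-fold lower number from compound 1 to compound 3 (0.50 log units; beyond the scatter). These steps pull in opposite directions, so no change beyond the scatter is expected, with a slight lean towards a higher number.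

The expected result is a 1.3-fold higher number from compound 3 to compound 4 (0.11 log units; within the scatter) in this assay.

For compound 4 the estimated value is 10000 nM, with an expected range from 3000 nM to 25000 nM.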

Compound 4, half-maximal effective concentration: 3000 nM
Compound 4: the middle estimate sits 3.3-fold (0.52 log units) above what was measured; the range from low to high includes it.
By their numbers in this assay, from the lowest: compounds 2 and 4 (each within the scatter of the next); then compound 3. At a limit, above all of these: compound 1.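

In this assay, a free acid at the end of the chain carries no penalty at this position, para to a large group: 2-carboxyethenyl in place of cyano gave a 2.6-fold lower number from compound 3 to compound 4 (0.41 log units; beyond the scatter), and removing the ethyl from the ester gave a 1.8-fold higher number from compound 2 to compound 4 (0.25 log units; within the scatter), so compound 2 and compound 4 cannot be told apart here. The sulfo group and the 2-carboxyethenyl group also part ways, with an at least 8.3-fold lower number from compound 1 to compound 4 (0.92 log units; beyond the scatter). Compound 1 stands at a limit, so the true size of that step is unknown: the limit of > 25000 nM in this assay, at which 1 of the 4 values shown sits.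

Still open, going by these compounds, is whether the step from cyano belongs to the ethenyl chain or to the acid at its end. A saturated 2-carboxyethyl chain or an amine at this position would help to separate the two.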